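Swapping a terminal amine for imidazole on a lipopeptide

The source may report more compounds than this note shows. Statements on the series, on what has been measured and on what is new or still open speak of the compounds shown alone.

Compound 1, `CCCCCCCCCCCC(=O)OC[C@H](CSC[C@@H](N)C(=O)NCCOCCOS(=O)(=O)O)OC(=O)CCCCCCCCCCC` — in an assay on HEK293 cells for agonist activity at Toll-like receptor 2 (Homo sapiens) (on this read-out higher numbers stand for an effect only at larger amounts of compound and lower numbers for an effect already at smaller amounts), compound 1 gives 61 nM.
Compound 2, `CCCCCCCCCCCC(=O)OC[C@H](CSC[C@@H](N)C(=O)NC(C)CCC(C)C)OC(=O)CCCCCCCCCCC` — in this assay compound 2 gives 190 nM.
Compound 3, `CCCCCCCCCCCC(=O)OC[C@H](CSC[C@@H](N)C(=O)NCCCCN)OC(=O)CCCCCCCCCCC` — in this assay compound 3 gives 1040 nM.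

Among the measured compounds shown here, compound 3 stands highest of the three numbers measured so far: a 17-fold higher number from compound 1 to compound 3 (1.23 log units; beyond the scatter), and a 5.5-fold higher number from compound 2 to compound 3 (0.74 log units; beyond the scatter). Both steps went from another group on the amide-type nitrogen to the 4-aminobutyl, and both raised the number beyond the scatter. Compound 4, `CCCCCCCCCCCC(=O)OC[C@H](CSC[C@@H](N)C(=O)NCCCn1ccnc1)OC(=O)CCCCCCCCCCC`, now alters that same group: 1H-imidazol-1-yl in place of aminomethyl on a saturated chain carbon, three bonds along the chain from an amide-type nitrogen. For the measured compounds named here, no measured pair involves an aromatic ring at this position, so the expectation for compound 4 rests only on the two steps into compound 3, which showed the 4-aminobutyl as the group with the highest number in both cases, the first of them large and the second modest. Moving away from that amine toward the imidazole is therefore expected to lower the number, and the step from compound 3 to compound 4 in this assay is estimated at a 3.5-fold lower number from compound 3 to compound 4 (0.54 log units; beyond the scatter). The size is uncertain; the estimate for compound 4 in this assay is 300 nM, with a range from 80 nM to 1200 nM.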

Compound 4, half-maximal effective concentration: 410 nM
Compound 4: the middle estimate sits 1.4-fold (0.14 log units) below what was measured; measured number inside the range.
By their numbers in this assay, from the lowest: compound 1; then compound 2; then compound 4; then compound 3.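

In this assay, replacing the terminal aminomethyl with 1H-imidazol-1-yl gives a 2.5-fold lower number from compound 3 to compound 4 (0.40 log units; beyond the scatter), so this position accepts a five-membered aromatic ring and the effect does not depend on the terminal amine. The change also removes the hydrogen-bond donor counted on the aminomethyl, yet the number improves rather than worsens. The ring still does not match the other two groups on the amide-type nitrogen, as a 2.2-fold higher number from compound 2 to compound 4 (0.33 log units; beyond the scatter) and a 6.7-fold higher number from compound 1 to compound 4 (0.83 log units; beyond the scatter) show, which places the 3-(1H-imidazol-1-yl)propyl compound among the higher numbers of the set but clear of the 4-aminobutyl.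

Nothing available explains why the imidazole gives a lower number than the amine. Going by these compounds, it also remains open whether a phenyl ring, a carboxylic acid, or a shorter or longer chain carrying the same imidazole would bring the number closer to that of compound 1, at 61 nM, or whether the gain is particular to this ring on this chain.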